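The compounds below may be only part of what the source reports. "The series", "measured", "known", "first", "only" and "open" are said of these compounds alone.

In a functional assay on corpus cavernosum (Rattus norvegicus) for activation (a lower number here means that less compound is needed, a higher number that more compound is needed for the effect), compound 3 (`CC(C)Oc1ccccc1-c1nc2c(cnn2-c2ccc(Br)cc2)c(=O)[nH]1`) gives 280 nM and lies within the scatter of compound 2 (`O=c1[nH]c(-c2ccccc2O)nc2c1cnn2-c1ccc(Br)cc1`), which gives 338 nM here. Compound 1 (`CCCCOc1ccccc1-c1nc2c(cnn2-c2ccccc2)c(=O)[nH]1`) gives 630 nM and stands higher than compound 3 by more than the scatter. Compound 4 (`CCCCOc1ccccc1-c1nc2c(cnn2-c2ccc(Br)cc2)c(=O)[nH]1`) has butyl in place of isopropyl on an oxygen on an aromatic ring. Within the data shown here, the one measured step at that oxygen (a 1.2-fold lower number from compound 2 to compound 3 (0.08 log units; within the scatter)) stayed within the scatter, with isopropyl in place of hydrogen. Among the measured compounds shown here, compound 1 also carries butyl there, but no measured step isolates butyl against isopropyl. No step beyond the scatter is therefore expected in this assay for this change. The expected step is a 1.1-fold higher number from compound 3 to compound 4 (0.06 log units; within the scatter) and lies within the scatter. Compound 4 is estimated at 320 nM with 150 nM to 650 nM as the expected range.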

Compound 4, half-maximal effective concentration: 4.89 nM
For compound 4 the middle estimate is 65-fold (1.82 log units) above the measured one, and the stated range ends above it.
By their numbers in this assay, from the lowest: compound 4; then compounds 3, 2 and 1 (each within the scatter of the next, the first and the last beyond it).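

In this assay the group on this oxygen matters far more than the within-scatter step a 1.2-fold lower number from compound 2 to compound 3 (0.08 log units; within the scatter) suggested: butyl in place of isopropyl gives a 57-fold lower number from compound 3 to compound 4 (1.76 log units; beyond the scatter), and butyl in place of hydrogen gives a 69-fold lower number from compound 2 to compound 4 (1.84 log units; beyond the scatter). With butyl on the oxygen, bromo in place of hydrogen on an aromatic carbon also gives a large step, a 130-fold lower number from compound 1 to compound 4 (2.11 log units; beyond the scatter).

From the compounds shown here alone, whether a longer chain such as pentyl, or a butyl chain ending in an amine, keeps so low a number remains open, as does the size of the bromo step with isopropyl on the oxygen. No evidence available here bears on the size of these steps.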